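The source may hold more compounds than are shown below. What is called first, only, known or untested is meant among the compounds shown, and "the series" means these compounds.

Measured so far in a functional assay on HepG2 cells (Homo sapiens) for cytotoxicity, with a stated time of 72 h; a higher number here means that more compound is needed for the effect, a lower number that less compound is needed:
- compound 1 (`C=C[C@@](C)(/C=C/c1ccc(Nc2ccccc2)cc1)CCC=C(C)C`) gives > 52000 nM as a limit
- compound 2 (`C=C[C@@](C)(/C=C/c1ccc(Nc2ccc(OC)c(F)c2)cc1)CCC=C(C)C`) gives > 52000 nM as a limit
- compound 3 (`C=C[C@@](C)(/C=C/c1ccc(Nc2c(F)cc(F)cc2F)cc1)CCC=C(C)C`) gives > 52000 nM as a limit

Compound 1 has no number in this assay and stands only at the limit > 52000 nM in these notes. For the measured compounds named here, it has no rank, and the whole data set comes down to the limit of > 52000 nM in this assay, at which 3 of the 3 values shown sit, as its single reading.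

Compound 4 (`C=C[C@@](C)(/C=C/c1ccc(Nc2ccc(C(F)(F)F)cc2)cc1)CCC=C(C)C`) differs from compound 1 by one change (trifluoromethyl in place of hydrogen on an aromatic carbon), with trifluoromethyl in place of hydrogen on an aromatic carbon, para to a large group.

The measured steps that bear on this also alter the phenyl on the nitrogen. The series offers a step that the two limits leave unreadable from compound 1 to compound 2 and a step that the two limits leave unreadable from compound 1 to compound 3 as its two steps from compound 1, and a step that the two limits leave unreadable from compound 2 to compound 3 as the step between the two substituted compounds. None of them has a size that can be carried over to compound 4. No step beyond the scatter is expected in either direction because the limit of > 52000 nM in this assay, at which 3 of the 3 values shown sit, is all that these three compounds show.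

The expected outcome is a step that the limit leaves unreadable from compound 1 to compound 4 in this estimate, and a report as a limit is the likeliest form.

For compound 4 the estimated value is 55000 nM with an expected range from 26000 nM to 110000 nM in this assay when it is measured.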

Compound 4, half-maximal effective concentration: > 52000 nM
Compound 4: a limit, no number (the forecaster's own chance of this, stated with the estimate: 80%); the middle value is on the limit's open side.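

In this assay compound 4 gives > 52000 nM, a limit and not a number. For the compounds shown here, compound 1 also stands only at a limit, and no step from compound 1 to compound 4 can be read. The compounds shown leave open whether the changes on the phenyl on the nitrogen differ at all in cytotoxicity, and how far any compound lies past the single reading: the limit of > 52000 nM in this assay, at which 4 of the 4 values shown sit.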